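A few compounds are considered here, and "the series" means these few. Any claim that something is new, unique, unknown or untested is made for them only; others in the source may bear on it.

The series shares the core seen in compound 1 `O=C(/C=C/c1ccc([N+](=O)[O-])cc1)Nc1cc(Sc2ncn[nH]2)c(O)c2ccccc12` and varies only the group on the amide carbonyl. In a functional assay on MDA-MB-231 cells (Homo sapiens) for antiproliferative activity, read by MTT assay, with a stated time of 48 h (a lower number here means a stronger inhibitor, a higher number a weaker inhibitor), compound 2 `O=C(Nc1cc(Sc2ncn[nH]2)c(O)c2ccccc12)c1ccc2ccccc2c1` gives 45100 nM. Compound 3 `COc1cccc(C(=O)Nc2cc(Sc3ncn[nH]3)c(O)c3ccccc23)c1` is reported in this assay only as a limit, > 100000 nM. Compound 1 likewise reaches only a limit in this assay, > 100000 nM. Among the measured compounds shown here, the one measured step that bears on the change from compound 3, an at least 2.2-fold higher number from compound 2 to compound 3 (0.34 log units; beyond the scatter), is itself bounded by the limit of > 100000 nM in this assay, at which 2 of the 3 values shown sit, so compound 3 stands at the weak end of what the numbers show and no finer placing within the set is possible.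

Compound 4 `O=C(/C=C/c1ccc(Cl)cc1)Nc1cc(Sc2ncn[nH]2)c(O)c2ccccc12` differs from compound 3 by 2-(4-chlorophenyl)ethenyl in place of 3-methoxyphenyl on a carbonyl carbon. For the measured compounds named here, no measured step connects a 3-methoxyphenyl to a 2-(4-chlorophenyl)ethenyl group on this carbonyl carbon. Among the measured compounds, compound 1 is the nearest in structure to compound 4 and sits at the limit. Compound 3 sits at the same limit. A step of an at least 1.1-fold lower number from compound 3 to compound 4 (0.04 log units; that floor lies within the scatter) is therefore expected, that is none beyond the scatter, with a substantial chance that this assay again reports only a limit. Compound 4 is estimated at 90000 nM, with a range from 30000 nM to 300000 nM.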

Compound 4, half-maximal inhibitory concentration: > 100000 nM
Compound 4 was reported as a limit; the forecaster's own chance of this, stated with the estimate: 60%; middle value at least 1.1-fold (0.04 log units) away from the limit.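

In this assay compound 4 is reported only as a limit, > 100000 nM. Measured against the naphthalen-2-yl amide, 2-(4-chlorophenyl)ethenyl on the carbonyl carbon gives an at least 2.2-fold higher number from compound 2 to compound 4 (0.34 log units; beyond the scatter), a second step out of that amide after the one to the 3-methoxyphenyl amide, and chloro in place of nitro on an aromatic carbon does not bring the 2-arylethenyl amides to a readable number. The steps linking compound 4 to compound 1 and to compound 3 cannot be read, and among the groups on this carbonyl carbon only naphthalen-2-yl yields a number, so the set offers no ranking below that one value because of where the values fall: the limit of > 100000 nM in this assay, at which 3 of the 4 values shown sit.

On these data alone, whether an amine or a carboxylic acid in place of chloro on the 2-arylethenyl group would bring a value into the readable range remains open. Among the compounds shown here, also open is whether the single number of compound 2 belongs to naphthalen-2-yl specifically or would also appear with a longer chain on the carbonyl carbon.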